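A few compounds are considered here, and "the series" means these few. Any claim that something is new, unique, unknown or untested is made for them only; others in the source may bear on it.

Measured in a functional assay on MDA-MB-468 cells (Homo sapiens) for inhibition, read by sulforhodamine B assay, with a stated time of 48 h, tested at 10 uM; a higher number here means a weaker effect of the compound at the concentration tested, a lower number a stronger effect:
compound 1 `COc1cc(Cl)cc(-c2nn(-c3cccc(NC(=O)Nc4ccc(Cl)c(C(F)(F)F)c4)c3)cc2-c2ccncc2)c1` — -14.4%
compound 2 `COc1cc(Cl)cc(-c2nn(-c3cccc(NC(=O)c4cccc(C(F)(F)F)c4)c3)cc2-c2ccncc2)c1` — 47%
compound 3 `O=C(Nc1cccc(-n2cc(-c3ccncc3)c(-c3cc(O)cc(Cl)c3)n2)c1)c1cc(C(F)(F)F)cc(C(F)(F)F)c1` — 31.2%

Compound 3 stands second highest of the three numbers; compound 2 lies nearest, a number beyond the scatter higher, and compound 1 furthest, well lower. For the measured compounds named here, the only measured step, a number 61.4 percentage points higher from compound 1 to compound 2 (beyond the scatter), concerns the carbonyl substituent and does not touch the oxygen on the aromatic ring.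

Compound 4 `COc1cc(Cl)cc(-c2nn(-c3cccc(NC(=O)c4cc(C(F)(F)F)cc(C(F)(F)F)c4)c3)cc2-c2ccncc2)c1` differs from compound 3 by methyl in place of hydrogen on an oxygen on an aromatic ring. Going by the values given here, no measured pair isolates this change; compound 2 also carries the methoxy but differs elsewhere. No step beyond the scatter is therefore expected in this assay, and the estimated step is a number 3.8 percentage points higher from compound 3 to compound 4 (within the scatter). For compound 4 the expected value is 35%, range 15% to 55%.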

Compound 4, a percentage reported as activity, at one concentration (the size of the read-out at that concentration, not a potency): 46.5%
The estimate for compound 4 lay 11.5 percentage points below the measured number, within the range that was stated.
By their numbers in this assay, from the lowest: compound 1; then compound 3; then compounds 4 and 2 (each within the scatter of the next).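

In this assay the change from hydroxy to methoxy on the aromatic ring can now be read directly: a number 15.3 percentage points higher from compound 3 to compound 4 (beyond the scatter), so methoxy goes with the weaker effect at the concentration tested, in this one pair. Trifluoromethyl in place of hydrogen on an aromatic carbon gives no such separation: a number 0.5 percentage points lower from compound 2 to compound 4 (within the scatter).

From the compounds shown here alone, whether an amine in place of the hydroxy would read closer to compound 3 or to compound 4 stays open. No measurement bearing on the cause of either step is at hand.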